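The compounds below may be only part of what the source reports. "The series", "measured", "known", "first", "only" and "open" are said of these compounds alone.

Compound 1 `CCCCCCCCCCCCCCCCCC(=O)Nc1nnc(S[C@@H]2O[C@H](CO)[C@H](O)[C@H](O)[C@H]2O)s1`: 67100 nM
Compound 2 `CCCCCCCCCCCCCCCC(=O)Nc1nnc(S[C@@H]2O[C@H](COC(C)=O)[C@H](OC(C)=O)[C@H](OC(C)=O)[C@H]2OC(C)=O)s1`: 25400 nM

In a functional assay on MDA-MB-231 cells (Homo sapiens) for cytotoxicity, read by MTT assay, with a stated time of 24 h (a higher number here means a weaker inhibitor, a lower number a stronger inhibitor), compound 1 gives 67100 nM, the higher of the two numbers, and so is the weaker inhibitor of the pair. The gap down to compound 2 at 25400 nM lies beyond the usual scatter, but these two compounds differ in more than one place, so it does not isolate any single change.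

Compound 3 `C=CCCCCCCCCC(=O)Nc1nnc(S[C@@H]2O[C@H](CO)[C@H](O)[C@H](O)[C@H]2O)s1` has not yet been measured. It comes from compound 1 by one change, vinyl in place of nonyl on a saturated chain carbon, eight bonds along the chain from a carbonyl carbon. For the measured compounds named here, no measured pair shows this change alone, so only a small move toward a lower number is expected, possibly within the scatter. The estimated change is a 1.7-fold lower number from compound 1 to compound 3 (0.22 log units; within the scatter) in this assay. For compound 3 the estimate is 40000 nM, with an expected range of 15000 nM to 100000 nM.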

Compound 3, half-maximal inhibitory concentration: 80600 nM
Beside the measured number, compound 3's estimate is 2.0-fold (0.30 log units) below it, within the range that was stated.
By their numbers in this assay, from the lowest: compound 2; then compounds 1 and 3 (each within the scatter of the next).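

In this assay, putting vinyl in place of nonyl on a saturated chain carbon, eight bonds along the chain from a carbonyl carbon, gives a 1.2-fold higher number from compound 1 to compound 3 (0.08 log units; within the scatter). For the compounds shown here, this is the first single-place comparison, and it shows that compound 1 and compound 3 cannot be told apart here, even though the two groups differ in size and vinyl brings a double bond. At this place in the chain, then, the assay does not distinguish nonyl from vinyl. Nothing available explains this result.

Going by these compounds alone, an amine or a carboxylic acid on this same chain carbon, or a longer chain than the one in compound 1, remains an open case. Going by these compounds, whether any single change to the shared core can move the number beyond the scatter also remains open.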